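The compounds below may be only part of what the source reports. "The series", "measured", "known", "first", "only" and "open" are said of these compounds alone.

In a functional assay on DU-145 cells (Homo sapiens) for inhibition, read by trypan blue exclusion, with a stated time of 96 h (a lower number here means a stronger inhibitor of growth, a higher number a weaker inhibitor of growth), three compounds sharing one core have been measured. Compound 2 (`Cc1ccc(S/C(=C/c2ccc(N(C)C)cc2)C(=O)c2ccc(Cl)cc2)cc1`) gives only a limit of the assay, > 100000 nM. Compound 3 (`CN(C)c1ccc(/C=C(/SCc2ccccc2Cl)C(=O)c2ccc(Cl)cc2)cc1`) likewise gives only a limit of the assay, > 100000 nM. Compound 1 (`Cc1ccc(CS/C(=C/c2c(O)cc(O)cc2O)C(=O)c2ccc(Cl)cc2)cc1`), which carries a 2,4,6-trihydroxyphenyl group, is the only one of the three with a number, 50000 nM.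

Among the measured compounds shown here, the one measured step from compound 2 is a step that the two limits leave unreadable from compound 2 to compound 3. It offers no size to carry forward, and the picture so far is dominated by the limit of > 100000 nM in this assay, at which 2 of the 3 values shown sit.

Compound 4 (`Cc1ccc(S/C(=C/c2c(O)cc(O)cc2O)C(=O)c2ccc(Cl)cc2)cc1`) keeps the rest of compound 2 and alters a single group: 2,4,6-trihydroxyphenyl in place of 4-(dimethylamino)phenyl on a double-bonded chain carbon bound to a double-bonded chain carbon. For the measured compounds named here, no measured step covers this exchange directly. The nearest guide is compound 1, which has 2,4,6-trihydroxyphenyl on the same double-bonded chain carbon and reads 50000 nM, so a compound with this group has given a number in this assay. A move towards stronger inhibition of growth is therefore expected, although its size remains uncertain with a limit as the starting point. The expected change is an at least 3.3-fold lower number from compound 2 to compound 4 (0.52 log units; beyond the scatter). For compound 4 the estimated value is 30000 nM, with an expected range from 6000 nM to 100000 nM.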

Compound 4, concentration for 50% growth inhibition: > 100000 nM
Compound 4: a limit, no number; the forecaster's own chance of this, stated with the estimate: 25%; at least 3.3-fold (0.52 log units) between middle value and limit.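

The 2,4,6-trihydroxyphenyl group on this double-bonded chain carbon does not by itself bring a number in this assay, since compound 4 also gives only a limit of the assay, > 100000 nM. The two compounds carrying this group are linked by the exchange of 4-methylbenzyl for 4-methylphenyl on a sulfur, an at least 2.0-fold higher number from compound 1 to compound 4 (0.30 log units; that floor lies within the scatter), so the change on the sulfur is not shown to be a firm loss, but the number seen with 4-methylbenzyl did not carry over to 4-methylphenyl. The steps from compound 2 cannot be read, and the picture remains dominated by a single limit: the limit of > 100000 nM in this assay, at which 3 of the 4 values shown sit.

The compounds shown leave open whether a longer chain on the sulfur, such as 2-phenylethyl, or a carboxylic acid on the aromatic ring attached there would give a clearer number than compound 1 does. They also leave open how far past the limit compound 4 lies, and so how large the change from 4-methylbenzyl to 4-methylphenyl really is.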